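A few compounds are considered here, and "the series" means these few. Any claim that something is new, unique, unknown or untested is made for them only; others in the source may bear on it.

Compound 1 `Nc1ccccc1NC(=O)c1ccc(CSC(=S)N2CCN(c3ccc(Cl)cc3)CC2)cc1`: 44.8%. Compound 2 `Nc1ccccc1NC(=O)c1ccc(CSC(=S)N2CCN(c3ccc(F)cc3)CC2)cc1`: 64.5%. Compound 3 `N#Cc1ccc(N2CCN(C(=S)SCc3ccc(C(=O)Nc4ccccc4N)cc3)CC2)cc1`: 70.6%.

All three were tested in a functional assay on HeLa cells (Homo sapiens) for antiproliferative activity, read by CCK-8 assay, with a stated time of 72 h, tested at 8 uM; on this read-out lower numbers stand for a weaker effect and higher numbers for a stronger effect at the one concentration tested. Compound 3 stands highest of the three numbers in this assay, although the step of a number 6.1 percentage points higher from compound 2 to compound 3 (within the scatter) is within the scatter, so compound 2 and compound 3 cannot be told apart on this read-out. The steps of a number 19.7 percentage points higher from compound 1 to compound 2 (beyond the scatter) and a number 25.8 percentage points higher from compound 1 to compound 3 (beyond the scatter) are beyond the scatter and both modest in size.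

Compound 4 `CN1CCN(C(=S)SCc2ccc(C(=O)Nc3ccccc3N)cc2)CC1` differs from compound 3 in one place: methyl in place of 4-cyanophenyl on an amine nitrogen in a ring. For the measured compounds named here, none of the measured steps bears directly on this change. Each of them exchanges one substituent for another on the aromatic ring that compound 4 no longer carries, and those exchanges moved the read-out in this assay by modest amounts at most. Taking away the whole 4-cyanophenyl group is a larger change than any of them, and the direction it takes is not fixed by the data. The account therefore expects a drop of moderate size, a number 20.6 percentage points lower from compound 3 to compound 4 (beyond the scatter), with wide uncertainty. For compound 4 the expected value in this assay is 50%, with a range from 25% to 75%.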

Compound 4, a percentage reported as inhibition, at one concentration (the size of the read-out at that concentration, not a potency): 75.7%
For compound 4 the middle estimate is 25.7 percentage points below the measured one; measured number above the stated range.
By their numbers in this assay, from the lowest: compound 1; then compounds 2, 3 and 4 (each within the scatter of the next, the first and the last beyond it).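

In this assay, the 4-cyanophenyl group on the ring nitrogen proves dispensable, since the step of a number 5.1 percentage points higher from compound 3 to compound 4 (within the scatter) shows that a methyl group, with no aromatic ring and far fewer heavy atoms, keeps the read-out level with that of the aryl compound. The same exchange gives a number 11.2 percentage points higher from compound 2 to compound 4 (beyond the scatter) against the 4-fluorophenyl compound and a number 30.9 percentage points higher from compound 1 to compound 4 (beyond the scatter) against the 4-chlorophenyl compound, so among these four compounds an aromatic ring at this position is not required for the effect at the one concentration tested, and the halogen-bearing rings do not exceed the small methyl group. No measured property of these compounds is available to explain why this position tolerates so large an exchange.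

What the compounds shown leave open is how other groups on this ring nitrogen would read, such as an ethyl group, a benzyl group, an unsubstituted phenyl ring or a plain hydrogen. They also leave open whether compound 3 and compound 4, which cannot be told apart at this single concentration, would show a stronger or weaker effect than each other at other concentrations.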